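The source may hold more compounds than are shown below. What is called first, only, known or untested is meant among the compounds shown, and "the series" means these compounds.

Measured so far:
compound 1 `O=S(=O)(NCCCNc1nccc(-c2c(-c3cccc(F)c3)nc3sccn23)n1)c1ccc(Br)cc1`: 9400 nM
compound 2 `O=S(=O)(NCCCNc1nccc(-c2c(-c3cccc(F)c3)nc3sccn23)n1)c1ccc(F)cc1`: > 20000 nM, a limit
compound 3 `O=S(=O)(NCCNc1nccc(-c2c(-c3cccc(F)c3)nc3sccn23)n1)c1ccccc1`: 19000 nM

In a functional assay on SK-MEL-28 cells (Homo sapiens) for cytotoxicity, read by MTT assay (a lower number here means a stronger inhibitor, a higher number a weaker inhibitor), compound 1 holds the lowest of the two numbers shown; the nearest is reached by a 2.0-fold higher number from compound 1 to compound 3 (0.31 log units; beyond the scatter). Compound 2 gives only a limit there, > 20000 nM (the limit of > 20000 nM in this assay, at which 1 of the 3 values shown sits).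

Compound 4 `O=S(=O)(NCCCNc1nccc(-c2c(-c3cccc(F)c3)nc3sccn23)n1)c1ccccc1` differs from compound 1 by hydrogen in place of bromo on an aromatic carbon. Among the compounds with values here, the step that bears most directly on this is an at least 2.1-fold higher number from compound 1 to compound 2 (0.32 log units; beyond the scatter), the one other change at the bromo with the chain kept. Also relevant is an at least 1.0-fold lower number from compound 2 to compound 3 (0.02 log units; that floor lies within the scatter), which holds the fluoro and the unsubstituted ring near each other across a chain change. A modest weakening is therefore expected, a 1.9-fold higher number from compound 1 to compound 4 (0.28 log units; within the scatter). Compound 4 is estimated at 18000 nM, with a range from 9000 nM to 30000 nM.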

Compound 4, half-maximal inhibitory concentration: 6850 nM
The estimate for compound 4 lay 2.6-fold (0.42 log units) above the measured number, outside the stated range (below it).
By their numbers in this assay, from the lowest: compounds 4 and 1 (each within the scatter of the next); then compound 3. At a limit, above all of these: compound 2.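

In this assay, the 4-bromophenyl and the phenyl cannot be told apart, a 1.4-fold lower number from compound 1 to compound 4 (0.14 log units; within the scatter), so the bromo is not needed at this place. Hydrogen in place of fluoro lowers the number, an at least 2.9-fold lower number from compound 2 to compound 4 (0.46 log units; beyond the scatter), and ((phenylsulfonyl)amino)methyl in place of (phenylsulfonyl)amino does too, a 2.8-fold lower number from compound 3 to compound 4 (0.44 log units; beyond the scatter). Compound 2 is held only at a limit, so the fluoro step has a floor and no exact size: the limit of > 20000 nM in this assay, at which 1 of the 4 values shown sits.

Open, as far as these compounds go, is whether a methoxy or an amine at this place would separate from hydrogen. Also open, from the compounds shown here alone, is whether a longer chain would lower the number further.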